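Swapping a Benzyl Arm for Isobutyl: Expected Cytotoxicity

The compounds below may be only part of what the source reports. "The series", "measured", "known", "first", "only" and "open" are said of these compounds alone.

Compound 2 `Nc1nc(NCc2ccccc2)c2ncn(/C=C3/CC3(CO)CO)c2n1` is one of three compounds tested in an ADME assay on BCBL1 cells (Homo sapiens) for cytotoxicity, with a stated time of 7 days; a lower number here means that less compound is tolerated, a higher number that more compound is tolerated. Among the measured compounds shown here, compound 2 gives 19900 nM, the only value here that is an actual number rather than a limit. Compound 1 `CC(C)CSc1nc(N)nc2c1ncn2/C=C1/CC1(CO)CO` reaches only a limit of the assay, > 20000 nM. Compound 3 `Nc1nc2c(ncn2/C=C2/CC2(CO)CO)c(=O)[nH]1` likewise sits at a limit, > 20000 nM. For the measured compounds named here, the single measured step, a number no higher from compound 1 to compound 2 (the limit leaves the size open), has a size that cannot be read because of the limit of > 20000 nM in this assay, at which 2 of the 3 values shown sit. Compound 4 `CC(C)CNc1nc(N)nc2c1ncn2/C=C1/CC1(CO)CO` differs from compound 2 by isopropyl in place of phenyl on a saturated chain carbon bound to a nitrogen on an aromatic ring. Going by the values given here, no measured step matches this exchange, so no shift beyond the usual scatter is expected in either direction. Compound 4 is estimated at 25000 nM, within 12000 nM to 60000 nM. The step of a 1.3-fold higher number from compound 2 to compound 4 (0.10 log units; within the scatter) is therefore expected to be small.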

Compound 4, half-maximal cytotoxic concentration: > 20000 nM
Compound 4: a limit, no number; the forecaster's own chance of this, stated with the estimate: 70%; the middle value lies beyond the limit too.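

In this assay compound 4 gives > 20000 nM, which is a limit and not a number. Isobutylamino on this aromatic carbon thus behaves like the isobutylsulfanyl of compound 1 in staying at the limit, and the benzyl arm can be exchanged for isobutyl with a number no lower from compound 2 to compound 4 (the limit leaves the size open). Neither new step has a readable size, because of where the values stop: the limit of > 20000 nM in this assay, at which 3 of the 4 values shown sit.

Going by these compounds, what stays open is whether any group at this place brings cytotoxicity clearly into the measurable range. A longer chain on the nitrogen, or a carboxylic acid on the benzyl ring, would test that.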